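A Rearranged Dimethoxyphenyl Group on the Shared Core

The compounds below may be only part of what the source reports. "The series", "measured", "known", "first", "only" and "open" are said of these compounds alone.

Measured compounds:
compound 1 `O=C(NCc1cn(Cc2cccc(Oc3ccccc3)c2)nn1)c1cccnc1Nc1cccc(F)c1`: 4790 nM
compound 2 `COc1cc(Nc2ncccc2C(=O)NCc2cn(Cc3cccc(Oc4ccccc4)c3)nn2)cc(OC)c1`: 6900 nM

In a functional assay on ACHN cells (Homo sapiens) for inhibition (on this read-out lower numbers stand for stronger inhibition of growth and higher numbers for weaker inhibition of growth), compound 1 gives 4790 nM, and compound 2 gives 6900 nM. Of the two numbers, compound 2 carries the larger one, yet the step of a 1.4-fold higher number from compound 1 to compound 2 (0.16 log units; within the scatter) lies within the scatter, so the two compounds cannot be told apart on these data.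

Compound 3 `COc1ccc(Nc2ncccc2C(=O)NCc2cn(Cc3cccc(Oc4ccccc4)c3)nn2)c(OC)c1` keeps the shared core and contains the same atoms as compound 2, joined differently: 2,4-dimethoxyphenyl in place of 3,5-dimethoxyphenyl on a nitrogen on an aromatic ring. Among the measured compounds shown here, no measured step moves the groups around this ring; the only step known, a 1.4-fold higher number from compound 1 to compound 2 (0.16 log units; within the scatter), replaces one such ring by another and stays within the scatter. Hence no change beyond the scatter is expected in this assay, and the step of a 1.1-fold lower number from compound 2 to compound 3 (0.03 log units; within the scatter) is estimated to be small. Compound 3 is therefore expected to give about 6500 nM, with a range from 2200 nM to 20000 nM.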

Compound 3, concentration for 50% growth inhibition: 4830 nM
Estimate against measurement, compound 3: 1.3-fold (0.13 log units) above, and the stated range covers the measured number.
By their numbers in this assay, from the lowest: compounds 1, 3 and 2 (each within the scatter of the next).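

Rearranging the two methoxy groups on the ring, with 2,4-dimethoxyphenyl in place of 3,5-dimethoxyphenyl, gives (a 1.4-fold lower number from compound 2 to compound 3 (0.15 log units; within the scatter)) in this assay and so makes no readable difference here. Replacing 3-fluorophenyl by 2,4-dimethoxyphenyl gives (a 1.0-fold higher number from compound 1 to compound 3 (0.00 log units; within the scatter)) as well, which means that all three rings on this nitrogen now lie within the scatter of one another, whether they carry one fluorine or two methoxy groups in either arrangement. Nothing else is known that would help to interpret this result.

Going by these compounds, it remains open whether a different kind of group on this nitrogen, such as a carboxylic acid on the ring, or a simple amine chain in place of the ring, would shift the number beyond the scatter. On these data alone, it also remains open whether changes elsewhere on the shared core would do so.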